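A Carbamoylphenyl Swap on an Amide Scaffold Without Measurable Effect

A few compounds are considered here, and "the series" means these few. Any claim that something is new, unique, unknown or untested is made for them only; others in the source may bear on it.

Compound 2 `Cc1cc(Cc2cccc(F)c2)c(=O)n(CC(=O)Nc2ccc(Br)cc2)n1` was tested in a functional assay on HL-60 cells (Homo sapiens), read by calcium flux; on this read-out lower numbers stand for an effect already at smaller amounts and higher numbers for an effect only at larger amounts of compound. In this assay compound 2 gives > 50000 nM, which is a limit of the assay rather than a number. Compound 1 `COc1ccc(Cc2cc(-c3ccc(OC)cc3)nn(CC(=O)Nc3ccc(Br)cc3)c2=O)cc1` shares the core. In this assay compound 1 gives > 50000 nM, also a limit. Both compounds sit at the limit of > 50000 nM in this assay, at which 2 of the 2 values shown sit, so neither shows a measurable effect in the tested range. Compound 3 `Cc1cc(Cc2ccc(C(N)=O)cc2)c(=O)n(CC(=O)Nc2ccc(Br)cc2)n1` has not yet been measured. It differs from compound 2 by one change: 4-carbamoylphenyl in place of 3-fluorophenyl on a saturated chain carbon bound to an aromatic carbon. Among the measured compounds shown here, no step between measured compounds is available, so the expectation rests only on compound 2 sitting at the limit. The step expected for compound 3, a step that the limit leaves unreadable from compound 2 to compound 3, is not expected to go beyond the scatter in either direction. Compound 3 is therefore estimated at 60000 nM, with a range from 20000 nM to 200000 nM, and most likely the assay again reports only a limit.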

Compound 3, half-maximal effective concentration: > 50000 nM
Compound 3 ended at the assay's limit; the forecaster's own chance of this, stated with the estimate: 80%; the middle value does not contradict the limit.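

No step can be read from compound 2 to compound 3 in this assay, because both end at a limit of the assay rather than at a number: the limit of > 50000 nM in this assay, at which 3 of the 3 values shown sit.

The compounds shown leave open which change to the shared core, if any, would give a measurable value.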